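The compounds below may be only part of what the source reports. "The series", "measured", "known", "first", "only" and "open" are said of these compounds alone.

Of the compounds shown here, three from one series have been tested in an ADME assay on HaCaT cells (Homo sapiens) for cytotoxicity, read by MTT assay, with a stated time of 72 h; on this read-out higher numbers stand for weaker inhibition and lower numbers for stronger inhibition. Compound 1 `Cc1cc(-c2ccccc2)n(/C(N)=N/S(=O)(=O)c2cc(C)c(Cl)cc2SCc2ccc(C(F)(F)F)cc2)n1` gives 18000 nM. Compound 2 `Cc1cc(S(=O)(=O)/N=C(\N)n2nccc2-c2ccccc2)c(SCc2ccc(C(F)(F)F)cc2)cc1Cl` gives 19000 nM, and compound 3 `Cc1cc(-c2ccccc2)n(/C(N)=N/S(=O)(=O)c2cc(C)c(Cl)cc2SCc2cccc(Cl)c2)n1` gives 18000 nM. Compound 2 carries the highest of the three numbers, but both others sit within the usual scatter of it: a 1.1-fold higher number from compound 1 to compound 2 (0.02 log units; within the scatter), and compound 3 differs from compound 2 by an equally small margin. Exchanging hydrogen for methyl on an aromatic carbon therefore left the read-out essentially unmoved, and so did the other change, where no change at the digits printed from compound 1 to compound 3 (within the scatter) accompanied 3-chlorophenyl in place of 4-(trifluoromethyl)phenyl on a saturated chain carbon bound to a sulfur.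

Compound 4 `Cc1ccc(CSc2cc(Cl)c(C)cc2S(=O)(=O)/N=C(\N)n2nccc2-c2ccccc2)cc1` has not yet been measured. It differs from compound 2 by methyl in place of trifluoromethyl on an aromatic carbon. Of the measured steps, no change at the digits printed from compound 1 to compound 3 (within the scatter) bears most directly on this, as it also reworks the (4-(trifluoromethyl)benzyl)sulfanyl group, and it showed nothing beyond the scatter. The other step lies elsewhere on the shared core and adds no direction. The expected step is accordingly no change at the digits printed from compound 2 to compound 4 (within the scatter). Compound 4 is thus estimated at 19000 nM, within a range from 9000 nM to 40000 nM.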

Compound 4, half-maximal inhibitory concentration: 20000 nM
Beside the measured number, compound 4's estimate is 1.1-fold (0.02 log units) below it; the measured number falls inside the stated range.
By their numbers in this assay, from the lowest: compounds 1, 3, 2 and 4 (each within the scatter of the next).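

In this assay, replacing trifluoromethyl with methyl on an aromatic carbon para to a large group gives a 1.1-fold higher number from compound 2 to compound 4 (0.02 log units; within the scatter). The earlier step at this end of the molecule, no change at the digits printed from compound 1 to compound 3 (within the scatter), exchanged the whole 4-(trifluoromethyl)phenyl for 3-chlorophenyl, so it could not show what a change of the para group alone does; here the ring and the place stay the same, while trifluoromethyl, with 4 heavy atoms, gives way to methyl, with 1 heavy atom, and the read-out still stays within the scatter. Nothing available accounts for this flat result, so the data record that the number did not shift, but not the reason.

The compounds shown leave open whether a group of another kind at this place, such as a carboxylic acid, an amine or a longer chain like butyl, would carry the number beyond the scatter. Also open, from the compounds shown here alone, is how a bare hydrogen at this position would read against methyl and trifluoromethyl on the same core.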